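The source may hold more compounds than are shown below. What is called first, only, known or untested is meant among the compounds shown, and "the series" means these compounds.

Measured so far in a physicochemical assay for lipophilicity, read by HPLC, with a stated time of 90 min, tested at 100 uM; on this read-out higher numbers stand for higher lipophilicity and lower numbers for lower lipophilicity: compound 1 `CC(C)C(=O)N1CCC(NC(=O)Nc2ccc(OC(F)(F)F)c(F)c2)CC1`, 4.73; compound 2 `Cc1occc1C(=O)N1CCC(NC(=O)Nc2ccc(OC(F)(F)F)cc2)CC1`, 4.3; compound 3 `CC[C@H](C)C(=O)N1CCC(NC(=O)Nc2ccc(OC(F)(F)F)c(Cl)c2)CC1`, 7.7.

Compound 2 stands lowest of the three in this assay; compound 1 lies nearest to it, beyond the scatter, and compound 3 furthest, well beyond it. Compound 4 `O=C(Nc1ccc(OC(F)(F)F)cc1)NC1CCN(C(=O)C2=COCC2)CC1` has not yet been measured. It differs from compound 2 in one place: a group of 5 heavy atoms (4 carbon, 1 oxygen; one five-membered non-aromatic ring with 1 hetero atom) in place of a group of 6 heavy atoms (5 carbon, 1 oxygen; one five-membered aromatic ring with 1 hetero atom), on a carbonyl carbon. Within the data shown here, no measured pair shows this kind of change, so the expected step rests on the change itself. A loss of one heavy atom and of the aromatic ring is expected to lower the number by a modest step, about at the edge of the scatter, giving a number 0.40 log units lower from compound 2 to compound 4 (beyond the scatter). Compound 4 is therefore estimated at 3.9 in this assay, within a range from 3.4 to 4.4.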

Compound 4, partition coefficient: 3.49
Compound 4: the middle estimate sits 0.41 log units above what was measured; low and high end bracket the measured number.
By their numbers in this assay, from the lowest: compound 4; then compound 2; then compound 1; then compound 3.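

In this assay, among these compounds, the step for placing the non-aromatic five-membered ring on the carbonyl carbon in place of 2-methylfuran-3-yl is a number 0.81 log units lower from compound 2 to compound 4 (beyond the scatter) and is the first that can be read at this position. It shows that this place alone can move the number beyond the scatter while the rest of the structure stays the same. No measurement at hand bears on why the step has this size.

This single step combines the loss of the methyl group with the loss of the aromatic ring, so their shares remain unseparated. Going by these compounds, how an unsubstituted furan-3-yl or a tetrahydrofuran-3-yl group would read on the same carbonyl carbon remains open.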